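Swapping cyclopropylmethoxy for bromo

The source may hold more compounds than are shown below. What is called first, only, known or untested is meant among the compounds shown, and "the series" means these compounds.

In a functional assay on SH-SY5Y cells (Homo sapiens) for antiproliferative activity, read by MTT assay, with a stated time of 48 h (on this read-out lower numbers stand for stronger inhibition of growth and higher numbers for weaker inhibition of growth), compound 3 `COc1ccccc1OCCNc1ccc(=O)n(Cc2ccc(OC)c(OCC3CC3)c2)n1` gives 10500 nM and holds the lowest number shown, while compound 1 `COc1ccccc1OCCNc1cnn(Cc2ccc(OC)c(OCC3CC3)c2)c(=O)c1Cl` gives 37900 nM as the nearest number. The value of compound 2 `COc1ccccc1OCCNc1ccc(=O)n(Cc2ccc(OC)c(OC3CCCC3)c2)n1` is a limit of the assay, > 100000 nM in this case. Compound 4 `COc1ccc(Cn2nc(NCCOc3ccccc3OC)ccc2=O)cc1Br` has bromo in place of cyclopropylmethoxy on an aromatic carbon and has not yet been measured. Going by the values given here, the one measured step at this place is an at least 9.5-fold lower number from compound 2 to compound 3 (0.97 log units; beyond the scatter) and it shows that the number responds strongly to the group there, though no step to bromo has been measured. A moderate rise is therefore expected, and the estimated step is a 2.9-fold higher number from compound 3 to compound 4 (0.46 log units; beyond the scatter) with wide uncertainty. Compound 4 is expected at 30000 nM within a range of 8000 nM to 100000 nM by this estimate.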

Compound 4, concentration for 50% growth inhibition: > 100000 nM
Compound 4: only a limit was reported; the forecaster's own chance of this, stated with the estimate: 20%; middle value at least 3.3-fold (0.52 log units) from the limit.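

In this assay, the change to bromo gives an at least 9.5-fold higher number from compound 3 to compound 4 (0.97 log units; beyond the scatter), so a second replacement of cyclopropylmethoxy, after cyclopentyloxy, also raises the number. Among the three groups shown at this place, cyclopropylmethoxy alone gives a value that is not a limit of the assay. The step between compound 2 and compound 4 cannot be read, because both values are limits: the limit of > 100000 nM in this assay, at which 2 of the 4 values shown sit. The compounds shown leave open whether an amine, a hydroxyl or a longer ether chain at this place would keep the number near that of compound 3.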